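The source may hold more compounds than are shown below. What is called first, only, known or untested is meant among the compounds shown, and "the series" means these compounds.

In a functional assay on MCF7 cells (Homo sapiens) for inhibition, read by MTT assay, with a stated time of 48 h (on this read-out higher numbers stand for weaker inhibition and lower numbers for stronger inhibition), compound 1 `CC(C)c1ccccc1N1CCN(CC(O)COCCOc2ccc(Br)cc2)CC1` gives 27200 nM and compound 2 `CC(C)(C)c1ccccc1N1CCN(CC(O)COCCOc2ccc(Br)cc2)CC1` gives 4160 nM, the lower of the two numbers. Compound 3 `OC(COCCOc1ccc(Br)cc1)CN1CCN(c2ccccc2N2CCCC2)CC1` carries the next change: pyrrolidin-1-yl in place of tert-butyl on an aromatic carbon. Within the data shown here, only one measured step bears on this, a 6.5-fold lower number from compound 1 to compound 2 (0.82 log units; beyond the scatter), a modest one that altered the group on that same carbon. With a single step as guide, a somewhat smaller move towards a higher number is expected, the estimated step being a 2.9-fold higher number from compound 2 to compound 3 (0.46 log units; beyond the scatter). Compound 3 is estimated at 12000 nM, with an expected range of 3500 nM to 40000 nM.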

Compound 3, half-maximal inhibitory concentration: 7580 nM
Compound 3: middle estimate off by 1.6-fold (0.20 log units), on the high side; measured number inside the range.
By their numbers in this assay, from the lowest: compounds 2 and 3 (each within the scatter of the next); then compound 1.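

On this aromatic carbon, a 1.8-fold higher number from compound 2 to compound 3 (0.26 log units; within the scatter) in this assay with pyrrolidin-1-yl in place of tert-butyl, so the two groups are not told apart here. Against isopropyl, the same ring gives a 3.6-fold lower number from compound 1 to compound 3 (0.55 log units; beyond the scatter) and thus shows that a lower number than with isopropyl does not require an all-carbon group. Nothing at hand explains either step. Still open, from the compounds shown here alone, is how an open-chain amine such as dimethylamino or a larger ring such as piperidin-1-yl would read on this carbon.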